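The compounds below may be only part of what the source reports. "The series", "measured", "known", "first", "only" and "open" are said of these compounds alone.

Measured compounds and their values in a functional assay on HepG2 cells (Homo sapiens) for inhibition, read by MTT assay, with a stated time of 24 h; a lower number here means a stronger inhibitor, a higher number a weaker inhibitor:

- compound 1 `CC1(C)[C@H]2CC[C@]1(C)N(Cc1cn(-c3ccc(Cl)cc3)nn1)C(=O)C2` gives 90 nM
- compound 2 `CC1(C)[C@H]2CC[C@]1(C)N(Cc1cn(-c3ccccc3O)nn1)C(=O)C2` gives 120 nM
- compound 3 `COc1ccc(-n2cc(CN3C(=O)C[C@@H]4CC[C@@]3(C)C4(C)C)nn2)cc1` gives 100 nM

All three share the same core and differ only in the aryl group on the aromatic nitrogen of the triazole. Compound 1 has the lowest number of the three, but its steps to both others are within the scatter, so no ordering of potency can be read from these data: the step of a 1.3-fold higher number from compound 1 to compound 2 (0.12 log units; within the scatter) and the step of a 1.1-fold higher number from compound 1 to compound 3 (0.05 log units; within the scatter) are both small, as is the step of a 1.2-fold lower number from compound 2 to compound 3 (0.08 log units; within the scatter).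

The next compound is compound 4 `CC1(C)[C@H]2CC[C@]1(C)N(Cc1cn(-c3cccc(O)c3)nn1)C(=O)C2`. It differs from compound 1 as follows: 3-hydroxyphenyl in place of 4-chlorophenyl on an aromatic nitrogen. The two measured steps that bear on this change are the exchange of 4-chlorophenyl for 2-hydroxyphenyl, a 1.3-fold higher number from compound 1 to compound 2 (0.12 log units; within the scatter), and the exchange of chloro for methoxy, a 1.1-fold higher number from compound 1 to compound 3 (0.05 log units; within the scatter). Neither a hydroxyl on the aryl ring nor removal of the chlorine has so far produced a step beyond the scatter in this assay. On that basis the step from compound 1 to compound 4 is expected to be a 1.2-fold higher number from compound 1 to compound 4 (0.09 log units; within the scatter), with no direction beyond the scatter. Compound 4 is therefore estimated at 110 nM, with a range of 55 nM to 230 nM.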

Compound 4, half-maximal inhibitory concentration: 70 nM
The estimate for compound 4 lay 1.6-fold (0.20 log units) above the measured number, within the range that was stated.
By their numbers in this assay, from the lowest: compounds 4, 1, 3 and 2 (each within the scatter of the next).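

Across the four aryl groups now on the aromatic nitrogen of the five-membered ring, the data in this assay show no step beyond the scatter, including when the hydroxyl sits at a different place on the phenyl ring, where the step is a 1.7-fold lower number from compound 2 to compound 4 (0.23 log units; within the scatter). The 3-hydroxyphenyl group carries 1 hydrogen-bond donor and 1 hydrogen-bond acceptor where 4-chlorophenyl carries 0 of each, yet that exchange gives only a 1.3-fold lower number from compound 1 to compound 4 (0.11 log units; within the scatter), and the exchange for 4-methoxyphenyl gives a 1.4-fold lower number from compound 3 to compound 4 (0.15 log units; within the scatter), so neither the type of substituent nor its place on the phenyl ring separates these compounds in this assay. No measurement is available that would explain these small steps.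

As far as these compounds go, it remains open whether an amine or a carboxylic acid on the phenyl ring, or a longer alkyl chain in place of the phenyl ring, would give a step beyond the scatter at this position. All four compounds share the same core, so they also leave open how changes to the core or to the methylene link to the five-membered ring would register in this assay.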